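Replacing the cyclohexyl on the sulfonyl sulfur of compound 2

This account rests on a few compounds, and the source may have more. Where it says the series, first, only, none or still open, it means among the compounds named here.

compound 1 `O=C(NCc1ccc(S(=O)(=O)c2cncc(C(F)(F)F)c2)cc1)N1Cc2ccncc2C1`: 13 mL/min/kg
compound 2 `O=C(NCc1ccc(S(=O)(=O)C2CCCCC2)cc1)N1Cc2ccncc2C1`: 16 mL/min/kg
compound 3 `O=C(NCc1ccc(S(=O)(=O)C2CCC(F)(F)CC2)cc1)N1Cc2ccncc2C1`: 6 mL/min/kg

In an ADME assay on microsomes from liver (Homo sapiens) for pharmacokinetics, read by LC-MS, with a stated time of 60 min, tested at 1 uM (on this read-out lower numbers stand for slow clearance and higher numbers for fast clearance), compound 2 gives the highest of the three numbers, but compound 1 stands within the scatter of it (a 1.2-fold higher number from compound 1 to compound 2 (0.09 log units; within the scatter)), and only compound 3 lies clearly apart (a 2.7-fold lower number from compound 2 to compound 3 (0.43 log units; beyond the scatter)). Compound 4 `O=C(NCc1ccc(S(=O)(=O)N2CC3(CCOCC3)C2)cc1)N1Cc2ccncc2C1` differs from compound 2 at the sulfonyl sulfur: a group of 9 heavy atoms (7 carbon, 1 nitrogen, 1 oxygen; one four-membered non-aromatic ring with 1 hetero atom, one six-membered non-aromatic ring with 1 hetero atom) in place of a group of 6 heavy atoms (6 carbon; one six-membered non-aromatic ring of carbon only), on a sulfonyl sulfur. Going by the values given here, no measured step tries a change of this kind. The steps that exist all exchange one group for another at the same sulfonyl sulfur: a 2.2-fold lower number from compound 1 to compound 3 (0.34 log units; beyond the scatter) and a 2.7-fold lower number from compound 2 to compound 3 (0.43 log units; beyond the scatter) are modest drops, while a 1.2-fold higher number from compound 1 to compound 2 (0.09 log units; within the scatter) stays within the scatter. With those steps reaching at most a modest size, the expectation for compound 4 is a step of similar or smaller size, more likely a lowering than a rise, though an outcome within the scatter remains possible; the estimated step is a 1.6-fold lower number from compound 2 to compound 4 (0.20 log units; within the scatter). Compound 4 is therefore estimated at 10 mL/min/kg, with a range from 4 mL/min/kg to 22 mL/min/kg.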

Compound 4, clearance: 13 mL/min/kg
Estimate against measurement, compound 4: 1.3-fold (0.11 log units) below, within the range that was stated.
By their numbers in this assay, from the lowest: compound 3; then compounds 1, 4 and 2 (each within the scatter of the next).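

Compound 4 brings a group holding both nitrogen and oxygen to the sulfonyl sulfur, where the earlier groups held neither oxygen nor a non-aromatic ring with a hetero atom, and in this assay the exchange for cyclohexyl leaves the number within the scatter (a 1.2-fold lower number from compound 2 to compound 4 (0.09 log units; within the scatter)). The exchange for 5-(trifluoromethyl)pyridin-3-yl does the same (no change at the digits printed from compound 1 to compound 4 (within the scatter)), so three quite different groups at this position now give numbers that cannot be told apart. Only 4,4-difluorocyclohexyl still stands clearly apart, and the new group gives a modest rise against it (a 2.2-fold higher number from compound 3 to compound 4 (0.34 log units; beyond the scatter)), which shows that this new group does not share the lower number of compound 3.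

No measurement shown explains why these groups behave as they do. As far as these compounds go, it remains open whether a morpholine or a tetrahydropyranyl group on the sulfonyl sulfur, or a cyclohexyl carrying a single fluorine, would join compound 3 or fall in with the other three compounds.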